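Nitro in place of chloro on the anilino ring

A few compounds are considered here, and "the series" means these few. Any claim that something is new, unique, unknown or untested is made for them only; others in the source may bear on it.

Three analogues sharing one core are compared in a functional assay on MCF7 cells (Homo sapiens) for antiproliferative activity, read by MTT assay, with a stated time of 72 h; on this read-out lower numbers stand for stronger inhibition of growth and higher numbers for weaker inhibition of growth. Compound 1 `Cn1nc(-c2ccnc(Nc3cccc(O)c3)n2)c2ccccc21` carries a hydroxy group and in this assay compound 1 gives 28200 nM. Compound 2 `Cc1cccc(Nc2nccc(-c3nn(C)c4ccccc34)n2)c1` carries a methyl group in that position, and in this assay compound 2 gives 9150 nM. Compound 3 `Cn1nc(-c2ccnc(Nc3cccc(Cl)c3)n2)c2ccccc21` carries a chloro group, and in this assay compound 3 gives 5970 nM, the lowest number of the three. The step of a 4.7-fold lower number from compound 1 to compound 3 (0.67 log units; beyond the scatter) lies beyond the scatter, whereas the step of a 1.5-fold lower number from compound 2 to compound 3 (0.19 log units; within the scatter) lies within it, so compound 3 and compound 2 cannot be ranked against each other.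

Compound 4 `Cn1nc(-c2ccnc(Nc3cccc([N+](=O)[O-])c3)n2)c2ccccc21` is not yet measured. It differs from compound 3 by nitro in place of chloro on an aromatic carbon. Among the compounds with values here, no measured step replaces a halogen with a nitro group, so the bearing of the earlier steps is indirect: the two steps away from the hydroxy group, a 3.1-fold lower number from compound 1 to compound 2 (0.49 log units; beyond the scatter) and a 4.7-fold lower number from compound 1 to compound 3 (0.67 log units; beyond the scatter), were modest, and the chloro-to-methyl comparison was within the scatter. On this basis compound 4 is expected to stay close to compound 3, and compound 4 is expected to show a 1.1-fold higher number from compound 3 to compound 4 (0.04 log units; within the scatter). In this assay compound 4 is therefore estimated at 6500 nM, with a range from 2200 nM to 19000 nM.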

Compound 4, concentration for 50% growth inhibition: 580 nM
The estimate for compound 4 lay 11-fold (1.05 log units) above the measured number, outside the stated range (below it).
By their numbers in this assay, from the lowest: compound 4; then compounds 3 and 2 (each within the scatter of the next); then compound 1.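

In this assay this position proved far more sensitive to the choice of group than the hydroxy, methyl and chloro analogues had shown: the earlier steps were modest or within the scatter, whereas a 10-fold lower number from compound 3 to compound 4 (1.01 log units; beyond the scatter) is large. The nitro group also stands clear of the other two groups, with a 16-fold lower number from compound 2 to compound 4 (1.20 log units; beyond the scatter) and a 49-fold lower number from compound 1 to compound 4 (1.69 log units; beyond the scatter) both large, so compound 4 is the most potent of the four. The nitro group brings more heavy atoms than chloro and two hydrogen-bond acceptors, but no measurement given here ties the large step to either count or to anything else.

The compounds shown leave open whether the large step is particular to the nitro group or would also appear with another group at this position, such as a nitrile, an amine or a carboxylic acid. They also leave open whether the nitro group would give a similar number at another place on the same ring, and whether the step would carry over to a different core.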